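A few compounds are considered here, and "the series" means these few. Any claim that something is new, unique, unknown or untested is made for them only; others in the source may bear on it.

Measured so far:
- compound 1, `COc1ccc(-c2cc(/C=C/C(=O)c3ccc(N)cc3)[nH]n2)cc1`: -67%
- compound 2, `COc1ccc(C(=O)/C=C/c2cc(-c3cc(OC)c(OC)c(OC)c3)n[nH]2)cc1`: -29%

In a functional assay on IGROV-1 cells (Homo sapiens) for cytotoxicity, read by sulforhodamine B assay, with a stated time of 48 h, tested at 100 uM (on this read-out higher numbers stand for a weaker effect at the one concentration tested and lower numbers for a stronger effect), compound 1 gives -67%, the lowest of the two numbers recorded. In this assay compound 2 gives -29%, a reading that lies well beyond the scatter above that of compound 1, so of the two measured compounds, compound 1 shows the stronger effect at the single concentration tested. Going by the values given here, no step between structures differing in one place has been measured, so the pair says only what its two numbers show.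

Compound 3, `COc1ccc(-c2cc(/C=C/C(=O)c3ccc(N)cc3)[nH]n2)cc1OC`, has not yet been measured in this assay. It differs from compound 1 by methoxy in place of hydrogen on an aromatic carbon. Among the compounds with values here, with no measured step of this kind to lean on, the expected step of a number 12 percentage points higher from compound 1 to compound 3 (beyond the scatter) is small and toward a weaker effect, within or just beyond the scatter. For compound 3 the estimated reading in this assay is -55%, with a range from -90% to -15%.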

Compound 3, a percentage reported as activity, at one concentration (the size of the read-out at that concentration, not a potency): -62%
Estimate against measurement, compound 3: 7 percentage points above; low and high end bracket the measured number.
By their numbers in this assay, from the lowest: compounds 1 and 3 (each within the scatter of the next); then compound 2.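

The step for methoxy in place of hydrogen on an aromatic carbon is a number 5 percentage points higher from compound 1 to compound 3 (within the scatter) in this assay. Going by these compounds alone, this is the first step between structures differing in one place, and it shows that this position, ortho to a methoxy group and meta to a large group, accepts a methoxy with no change that can be told from the usual scatter at the single concentration tested. Nothing measured here bears on why the reading holds at this position.

From the compounds shown here alone, what remains open is whether a hydroxyl, a chlorine or a longer chain such as ethoxy at the same position would also leave the reading within the scatter of compound 1. A single step at one concentration also leaves open whether compound 1 and compound 3 would differ in potency.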